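Moving from pyridin-3-yl to 1,2-thiazol-4-yl on the shared core

The source may hold more compounds than are shown below. What is called first, only, known or untested is meant among the compounds shown, and "the series" means these compounds.

The measured compounds:
compound 1, `c1ccc(-c2ccc(CCc3nc(CC4CCCC4)c[nH]3)cc2)nc1`, 177 nM
compound 2, `CCC(C)(C)Cc1c[nH]c(CCc2ccc(-c3csnn3)cc2)n1`, 45 nM
compound 3, `CCC(C)(C)Cc1c[nH]c(CCc2ccc(-c3cccnc3)cc2)n1`, 7.5 nM

All three numbers come from an in vitro assay on CHO cells for displacement of a labelled ligand from Bombesin receptor subtype-3 (Homo sapiens), read by scintillation counting, with a stated time of 2 h; a higher number here means a weaker inhibitor, a lower number a stronger inhibitor. Compound 3 stands lowest of the three, with compound 2 nearest and compound 1 furthest, and both gaps are beyond the scatter. Compound 4, `CCC(C)(C)Cc1c[nH]c(CCc2ccc(-c3cnsc3)cc2)n1`, has not been measured. It differs from compound 3 as follows: 1,2-thiazol-4-yl in place of pyridin-3-yl on an aromatic carbon.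

Within the data shown here, one measured step bears on this change: a 6.0-fold lower number from compound 2 to compound 3 (0.78 log units; beyond the scatter), where a five-membered ring carrying two hetero atoms gave way to pyridin-3-yl. The change to compound 4 goes the other way, returning to a five-membered aromatic ring with 2 hetero atoms, though not the same one as in compound 2. The expectation is therefore a step back toward the number of compound 2. The entering ring is not identical to that of compound 2, and the expected step is set somewhat smaller than the measured one. The expected step is a 3.3-fold higher number from compound 3 to compound 4 (0.52 log units; beyond the scatter). In this assay compound 4 is expected to give 25 nM, within a range from 8 nM to 80 nM.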

Compound 4, half-maximal inhibitory concentration: 10 nM
Compound 4: the middle estimate sits 2.5-fold (0.40 log units) above what was measured, within the range that was stated.
By their numbers in this assay, from the lowest: compounds 3 and 4 (each within the scatter of the next); then compound 2; then compound 1.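

In this assay, replacing pyridin-3-yl with 1,2-thiazol-4-yl gives a 1.3-fold higher number from compound 3 to compound 4 (0.12 log units; within the scatter), so at this place, para to a large group, a five-membered aromatic ring with 2 hetero atoms can match the six-membered ring. Ring size alone therefore does not set the number, as a 4.5-fold lower number from compound 2 to compound 4 (0.65 log units; beyond the scatter) separates two five-membered rings, and the 1,2,3-thiadiazol-4-yl of compound 2 goes against any rule that all such rings fall behind pyridin-3-yl. Nothing available explains why these two five-membered rings differ.

The compounds shown leave open how a plain phenyl, a pyrimidin-5-yl or a 1,3-thiazol-5-yl ring would fare at this place. Steps to compound 1 cannot be read, since it differs from the others in more than one place, and whether an amine on the entering ring would be tolerated also remains open.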